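Working notes on the aryl ketone change in this series

The source may hold more compounds than are shown below. What is called first, only, known or untested is meant among the compounds shown, and "the series" means these compounds.

Measured compounds:
Compound 1, `Cc1ccc(C(=O)/C=C/c2ccc(/C=N/NC(=N)N)cc2)cc1`, gives 77.7% in a functional assay on the whole organism (Ear) for inhibition, with Mus musculus as the target, with a stated time of 30 min, at a dose of 100 mg/kg by the intraperitoneal route; a higher number here means more inhibition at the dose given (going by the name of the read-out), a lower number less inhibition.
Compound 2, `COc1ccc(C(=O)/C=C/c2ccc(/C=N/NC(=N)N)cc2)cc1`, gives 57.2% in this assay.

Within the data shown here, compound 2 stands lowest of the two numbers; its nearest neighbour is compound 1, and the one measured step, a number 20.5 percentage points lower from compound 1 to compound 2 (beyond the scatter), lies beyond the scatter. That step concerns only the substituent on the aryl ring attached to the carbonyl: methoxy in place of methyl on an aromatic carbon.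

Compound 3, `N=C(N)N/N=C/c1ccc(/C=C/C(=O)c2ccc(Cl)cc2Cl)cc1`, is not yet measured. It differs from compound 2 as follows: 2,4-dichlorophenyl in place of 4-methoxyphenyl on a carbonyl carbon. Among the measured compounds shown here, the only step that bears on this change is the one from compound 1 to compound 2, which shows that the 4-methoxyphenyl group went with the lower number. That step does not cover a chlorinated ring, so it is an indirect guide at best.

Given that compound 2 carries the lower of the two values because of a number 20.5 percentage points lower from compound 1 to compound 2 (beyond the scatter), a change away from 4-methoxyphenyl is expected to move compound 3 upward, with a number 10.8 percentage points higher from compound 2 to compound 3 (beyond the scatter). Compound 3 is therefore estimated at 68%, within the range 45% to 88%.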

Compound 3, a percentage reported as inhibition, in the whole organism at one dose (the size of the read-out at that dose, not a potency): 92.5%
Compound 3: the middle estimate sits 24.5 percentage points below what was measured; measured number above the stated range.
By their numbers in this assay, from the lowest: compound 2; then compound 1; then compound 3.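

In this assay, the group on the carbonyl carbon has more upward room than the first two compounds showed: 2,4-dichlorophenyl in place of 4-methylphenyl gives a number 14.8 percentage points higher from compound 1 to compound 3 (beyond the scatter), so 4-methylphenyl does not mark the top of the range at this position. The change away from 4-methoxyphenyl is the larger of the two new steps, at a number 35.3 percentage points higher from compound 2 to compound 3 (beyond the scatter), and the three groups now fall in a single order, from 4-methoxyphenyl through 4-methylphenyl to 2,4-dichlorophenyl, with every step between them beyond the scatter. No measured evidence is available to account for this order.

Both chlorine atoms enter together in compound 3, so the compounds shown leave open what each contributes alone, a question that a 4-chlorophenyl group on the same carbonyl carbon would help to answer. Also open, on these data alone, is where groups of another kind, such as a 4-aminophenyl group or a 4-carboxyphenyl group, would fall in this order, and whether the order holds at other doses, since all three numbers come from a single dose.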